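The source may hold more compounds than are shown below. What is called first, only, known or untested is meant among the compounds shown, and "the series" means these compounds.

Compound 1 `CC(C)Oc1cccc(C(O)(c2ccc(Cl)cc2)c2cccnc2)c1` and compound 2 `N#Cc1cccc(C(O)(c2ccc(Cl)cc2)c2cccnc2)c1` share one core. In an ADME assay on L6 cells (Rattus norvegicus) for cytotoxicity, read by resazurin assay, with a stated time of 72 h (a higher number here means a weaker inhibitor, a lower number a stronger inhibitor), compound 1 gives 67600 nM as a measured number. Compound 2 gives > 100000 nM as a limit of the assay and not as a number. Compound 3 `NC(=O)c1cccc(C(O)(c2ccc(Cl)cc2)c2cccnc2)c1` keeps that core and differs from compound 2 by carbamoyl in place of cyano on an aromatic carbon in one place: carbamoyl in place of cyano on an aromatic carbon, meta to a large group. Among the measured compounds shown here, the one measured step that bears on this change, cyano in place of isopropoxy, is an at least 1.4-fold higher number from compound 1 to compound 2 (0.17 log units; that floor lies within the scatter) and gives only a floor, not a true size. With so little to go on, the expected result in this assay is a number no higher from compound 2 to compound 3 (the limit leaves the size open) and thus no shift beyond the scatter in either direction. The estimate for compound 3 is 100000 nM with an expected range from 45000 nM to 200000 nM and a good chance of only a limit again.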

Compound 3, half-maximal inhibitory concentration: > 100000 nM
Compound 3: a limit, no number; the forecaster's own chance of this, stated with the estimate: 70%; the middle value lies on the limit itself.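

In this assay, carbamoyl in place of isopropoxy on this aromatic carbon, meta to a large group, gives an at least 1.4-fold higher number from compound 1 to compound 3 (0.17 log units; that floor lies within the scatter). Compound 3 therefore shows that a second group at this position, one that brings a hydrogen-bond donor which cyano lacks, also gives no measured number in this assay. The step from compound 2 to compound 3 cannot be read, because both compounds sit at the same ceiling: the limit of > 100000 nM in this assay, at which 2 of the 3 values shown sit.

Among the compounds shown here, compound 1 remains the only compound here with a measured number, so how far compound 2 and compound 3 truly differ from it, or from each other, stays open. Also open, from the compounds shown here alone, is whether an amine or a carboxylic acid at this position would give a measured number, and how that number would compare with compound 1.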